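Thian-4-yl in place of 4-chlorobenzyl: working notes

A few compounds are considered here, and "the series" means these few. Any claim that something is new, unique, unknown or untested is made for them only; others in the source may bear on it.

Measured in a functional assay on the whole organism for inhibition, with Rattus norvegicus as the target; a higher number here means that more compound is needed for the effect, a lower number that less compound is needed:
- compound 1 `CC(C)c1ccc(OC(C)(Cc2ccc(Cl)cc2)C(=O)O)cc1`: 1 mg/kg; 1 mg/kg; 1 mg/kg (3 entries)
- compound 2 `CC(Cc1ccc(Cl)cc1)(Oc1ccc(Cc2ccccc2)cc1)C(=O)O`: 1 mg/kg
- compound 3 `CC(Cc1ccc(Cl)cc1)(Oc1ccc(Cc2ccc(Cl)cc2)cc1)C(=O)O`: > 10 mg/kg (a limit)

Compound 3 stands at > 10 mg/kg, which is a limit and not a number. Within the data shown here, it is the only one of the three compounds without a single number in this assay.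

The next compound is compound 4 `CC(Cc1ccc(Cl)cc1)(Oc1ccc(C2CCSCC2)cc1)C(=O)O`, not yet measured. The change is thian-4-yl in place of 4-chlorobenzyl on an aromatic carbon.

Among the measured compounds shown here, one measured step bears on this change: an at least 10-fold higher number from compound 2 to compound 3 (1.00 log units; beyond the scatter), with chloro in place of hydrogen on an aromatic carbon. That step lies beyond the scatter, and compound 4 gives up that same chloro along with the rest of the 4-chlorobenzyl group. Without that chloro, compound 2 gives 1 mg/kg. Compound 1, which also lacks it, gives 1 mg/kg; 1 mg/kg; 1 mg/kg (3 entries).

A step of similar size in the opposite direction is therefore expected, towards a lower number in this assay. For the measured compounds named here, no measured compound carries thian-4-yl, so the size remains uncertain and another limit is possible.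

The expected change is an at least 5.0-fold lower number from compound 3 to compound 4 (0.69 log units; beyond the scatter). The estimate for compound 4 is 2 mg/kg, with an expected range of 0.5 mg/kg to 10 mg/kg.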

Compound 4, dose for half-maximal effect: < 10 mg/kg
Compound 4 gave a limit, no number; the forecaster's own chance of this, stated with the estimate: 20%; the middle value lies beyond the limit too.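

In this assay compound 4 gives < 10 mg/kg, which is a limit and not a number. Compound 3 gives > 10 mg/kg, which is also a limit. Read together, the two limits show that thian-4-yl, a six-membered non-aromatic ring with a hetero atom, in place of 4-chlorobenzyl on an aromatic carbon, para to a large group, gives a number no higher from compound 3 to compound 4 (the limit leaves the size open), but neither the size of that change nor the size of the change from the benzyl group of compound 2 can be read.

From the compounds shown here alone, whether compound 4 reaches the level of compound 2, which gives 1 mg/kg, stays open. Also open is what the ring sulfur contributes, as the compounds shown include no ring with oxygen in its place, no piperidine amine and no sulfone.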